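Bromo to cyano on the 4-bromophenyl compound

A few compounds are considered here, and "the series" means these few. Any claim that something is new, unique, unknown or untested is made for them only; others in the source may bear on it.

compound 1 `COC(=O)C1=C(C)N=C(C)/C(=C(\O)OC)C1c1cccc(Br)c1` gives 1.29 nM
compound 2 `COC(=O)C1=C(C)N=C(C)/C(=C(\O)OC)C1c1cccc(Cl)c1Cl` gives 19.1 nM
compound 3 `COC(=O)C1=C(C)N=C(C)/C(=C(\O)OC)C1c1ccc(Br)cc1` gives 540 nM

In a functional assay (muscle tissue) with Cavia porcellus as the target (a higher number here means that more compound is needed for the effect, a lower number that less compound is needed), compound 3 stands at 540 nM as the highest of the three numbers. Compound 4 `COC(=O)C1=C(C)N=C(C)/C(=C(\O)OC)C1c1ccc(C#N)cc1` has cyano in place of bromo on an aromatic carbon, para to a large group (cyano in place of bromo on an aromatic carbon). For the measured compounds named here, no measured step makes this exchange. The nearest steps (a 420-fold higher number from compound 1 to compound 3 (2.62 log units; beyond the scatter)) and (a 28-fold higher number from compound 2 to compound 3 (1.45 log units; beyond the scatter)) are both large, but each alters where the phenyl ring is substituted, and here that place stays the same. A smaller step is therefore expected, tentatively towards a higher number (a 1.3-fold higher number from compound 3 to compound 4 (0.11 log units; within the scatter)). Compound 4 is estimated at 700 nM (expected range 150 nM to 3000 nM).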

Compound 4, half-maximal effective concentration: 3470 nM
The estimate for compound 4 lay 5.0-fold (0.70 log units) below the measured number, outside the stated range (above it).
By their numbers in this assay, from the lowest: compound 1; then compound 2; then compound 3; then compound 4.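

In this assay, exchanging bromo for cyano while the place on the aromatic ring stays the same still moves the number beyond the scatter (a 6.4-fold higher number from compound 3 to compound 4 (0.81 log units; beyond the scatter)), so the nature of the group at this place matters as well as where the phenyl ring is substituted. Compound 4 now has the highest number of the set (a 180-fold higher number from compound 2 to compound 4 (2.26 log units; beyond the scatter); a 2700-fold higher number from compound 1 to compound 4 (3.43 log units; beyond the scatter)). No measurement on hand accounts for this change.

From the compounds shown here alone, it remains open whether cyano in place of bromo moves the number the same way on the 3-bromophenyl of compound 1. Going by these compounds, how an amine or a carboxylic acid would read at this place is also open.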